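Amino for Chloro on a Shared Core: An Expected Outcome

The source may report more compounds than this note shows. Statements on the series, on what has been measured and on what is new or still open speak of the compounds shown alone.

Compound 1 `Nc1nn(C(=O)Nc2ccc(Cc3ccccc3)cc2)c2ccccc12` and compound 2 `Nc1nn(C(=O)Nc2ccc(Cc3ccccc3)cc2)c2ccc(Cl)cc12` are built on the same core and differ from each other in a single place. In a functional assay on MOLT-4 cells (Homo sapiens) for antiproliferative activity, read by sulforhodamine B assay, with a stated time of 48 h (a higher number here means that more compound is tolerated, a lower number that less compound is tolerated), compound 1 gives > 100000 nM, which is a limit of the assay rather than a measured number. Compound 2 likewise reaches a limit, giving > 100000 nM in this assay. The step that the two limits leave unreadable from compound 1 to compound 2 therefore cannot be read in size, since the limit of > 100000 nM in this assay, at which 2 of the 2 values shown sit, holds both values. Where compound 2 stands in this assay is thus known only as a limit.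

Compound 3 `Nc1ccc2c(c1)c(N)nn2C(=O)Nc1ccc(Cc2ccccc2)cc1` is the compound still to be measured. It differs from compound 2 by amino in place of chloro on an aromatic carbon. Going by the values given here, the single measured step, a step that the two limits leave unreadable from compound 1 to compound 2, touches the same place on the core and yields no readable size. With both measured neighbours sitting at the limit, the step that the limit leaves unreadable from compound 2 to compound 3 is expected to be none beyond the scatter, and compound 3 is expected to remain at the limit as well. For compound 3 the estimate in this assay is 150000 nM, with a range from 50000 nM to 500000 nM.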

Compound 3, concentration lethal to 50% of the cells: > 100000 nM
Compound 3 gave a limit, no number (the forecaster's own chance of this, stated with the estimate: 85%); the middle value is on the limit's open side.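

Compound 3 also gives only a limit in this assay, so the steps to it from compound 1 and compound 2 cannot be read in size: the limit of > 100000 nM in this assay, at which 3 of the 3 values shown sit. The compounds shown leave open how far past this limit compound 1, compound 2 and compound 3 each lie, and whether chloro or amino in place of hydrogen changes anything.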